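Swapping a side chain on an oral pain-relief scaffold

This account rests on a few compounds, and the source may have more. Where it says the series, first, only, none or still open, it means among the compounds named here.

Measured so far:
compound 1 `CSCC[C@H](NC(=O)CN(c1nc(Cl)nc2[nH]cnc12)C1CC1)C(=O)OCc1ccccc1`: 44.6%
compound 2 `CC(C)C[C@H](NC(=O)CN(c1nc(Cl)nc2[nH]cnc12)C1CC1)C(=O)OCc1ccccc1`: 15.2%
compound 3 `CC(C)C[C@H](NC(=O)CN(c1ncnc2c1ncn2C1CCCCO1)C1CC1)C(=O)OCc1ccccc1`: 28.2%

All three were tested in a functional assay on the whole organism (Tail, strain ICR) with Mus musculus as the target, in the tail flick test, with a stated time of 90 min, at a dose of 25 umol/kg by the oral route; a lower number here means a weaker effect, a higher number a stronger effect of the compound at the dose given. Compound 2 and compound 1 share a core and differ only by (methylsulfanyl)methyl in place of isopropyl on a saturated chain carbon, two bonds along the chain from an amide-type nitrogen and a carbonyl carbon. That swap gave a number 29.4 percentage points higher from compound 2 to compound 1 (beyond the scatter). Compound 3 carries a different core from compound 2; the difference between the two cores is not broken down here, and in this assay compound 3 gives 28.2%.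

Compound 4 `CSCC[C@H](NC(=O)CN(c1ncnc2c1ncn2C1CCCCO1)C1CC1)C(=O)OCc1ccccc1` is not yet measured. It differs from compound 3 by (methylsulfanyl)methyl in place of isopropyl on a saturated chain carbon, two bonds along the chain from an amide-type nitrogen and a carbonyl carbon, the same kind of change as from compound 2 to compound 1. Because the earlier step was a number 29.4 percentage points higher from compound 2 to compound 1 (beyond the scatter), a step of similar direction is expected here, though on the other core it may not be the same size. The expected step is a number 23.8 percentage points higher from compound 3 to compound 4 (beyond the scatter). Compound 4 is estimated at 52%, most likely between 32% and 72%.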

Compound 4, a percentage reported as activity, at one dose (the size of the read-out at that dose, not a potency): 42.7%
Compound 4: middle estimate off by 9.3 percentage points, on the high side; the measured number falls inside the stated range.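

In this assay, putting (methylsulfanyl)methyl in place of isopropyl gives a number 14.5 percentage points higher from compound 3 to compound 4 (beyond the scatter), so the direction of the change seen on the first core holds on the second. The size of the step does not carry over, and the two cores give clearly different gains: the same change on two cores in this assay, a number 29.4 percentage points higher (beyond the scatter) from compound 2 to compound 1 and a number 14.5 percentage points higher (beyond the scatter) from compound 3 to compound 4, 14.9 percentage points apart, beyond the scatter of two such steps

Within the data shown here, with only two pairs, this shows that the change helped on both of these cores, but not that it would help on a third core, and it does not explain why the gain differs.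

The compounds shown leave open what other groups on the same saturated chain carbon would do, such as an amine, a carboxylic acid or a longer chain. Going by these compounds, each number also comes from a single dose and a single time, so how the compounds compare at other doses remains unknown.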